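Swapping the chlorophenyl arm for a furan ring

A few compounds are considered here, and "the series" means these few. Any claim that something is new, unique, unknown or untested is made for them only; others in the source may bear on it.

Compound 1 `CC1=C(/C=C/C(=O)/C=C/c2ccccc2Cl)C(C)(C)CCC1` is assessed in a functional assay on HeLa cells (Homo sapiens) for cytotoxicity, read by sulforhodamine B assay, with a stated time of 48 h (a higher number here means a weaker inhibitor, a lower number a stronger inhibitor), where compound 1 gives 21800 nM. Two companions share its core and differ only in the group on the aromatic carbon: compound 2 `COc1ccccc1/C=C/C(=O)/C=C/C1=C(C)CCCC1(C)C` gives 88200 nM, and compound 3 `CC1=C(/C=C/C(=O)/C=C/c2ccccc2[N+](=O)[O-])C(C)(C)CCC1` gives 36100 nM. The steps among them are small to modest: a 4.0-fold higher number from compound 1 to compound 2 (0.61 log units; beyond the scatter), a 1.7-fold higher number from compound 1 to compound 3 (0.22 log units; within the scatter), and a 2.4-fold lower number from compound 2 to compound 3 (0.39 log units; beyond the scatter). Compound 1 therefore holds the lowest number of the three, although its gap to compound 3 sits within the scatter, so the two cannot be ordered.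

Compound 4 `CC1=C(/C=C/C(=O)/C=C/c2ccoc2)C(C)(C)CCC1` departs further from compound 1: furan-3-yl in place of 2-chlorophenyl on a double-bonded chain carbon bound to a double-bonded chain carbon. Within the data shown here, none of the measured steps replaces the whole aromatic ring; they only exchange one substituent on it, and even those exchanges moved the number by no more than a modest amount. Lacking a direct precedent, an estimate for compound 4 leans on the modest spread seen so far and allows for a somewhat higher number, with a step of a 1.8-fold higher number from compound 1 to compound 4 (0.26 log units; within the scatter) expected. Compound 4 is expected to give about 40000 nM, within a range from 12000 nM to 130000 nM.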

Compound 4, half-maximal inhibitory concentration: 88400 nM
Beside the measured number, compound 4's estimate is 2.2-fold (0.34 log units) below it, and the stated range covers the measured number.
By their numbers in this assay, from the lowest: compounds 1 and 3 (each within the scatter of the next); then compounds 2 and 4 (each within the scatter of the next).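

Exchanging the whole aromatic ring, not just a substituent on it, gave a 4.1-fold higher number from compound 1 to compound 4 (0.61 log units; beyond the scatter) in this assay. This places compound 4 with the methoxy compound 2, the two lying within the scatter of each other, while compounds 1 and 3 form the group with the lower numbers. The arm on the double-bonded chain carbon thus responds to a change of ring as well as to a change of substituent, but nothing measured here explains why furan-3-yl, with its five-membered ring and one hydrogen-bond acceptor, gives the higher number.

The compounds shown do not separate the loss of the chloro group from the change of ring, a distinction that an unsubstituted phenyl ring would address. They also leave open whether furan-2-yl, a thiophene ring or a pyridine ring would behave as furan-3-yl does.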